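The compounds below may be only part of what the source reports. "The series", "measured", "known", "first", "only" and "open" are said of these compounds alone.

Measured compounds:
Compound 1 `O=C1O/C(=C\Cn2cc(Br)c(=O)[nH]c2=O)C(OCc2ccccc2)=C1OCc1ccccc1` gives 7500 nM
Compound 2 `C=C(Cl)c1cn([C@H]2C[C@H](O)[C@@H](CO)O2)c(=O)[nH]c1=O` gives 1660 nM
Compound 3 `CC(O)Cn1cnc2c(Cl)nc(I)nc21` gives > 200000 nM

Of the compounds shown here, three have been tested in an ADME assay on L1210/0 cells (Mus musculus) for cytotoxicity, with a stated time of 48 h; on this read-out higher numbers stand for weaker inhibition and lower numbers for stronger inhibition. Compound 1 gives 7500 nM, while compound 2 gives 1660 nM, the lowest of the two numbers; the gap between them lies beyond the scatter. For compound 3 the result is only a limit, > 200000 nM, one of the three values sitting at that limit (the limit of > 200000 nM in this assay, at which 1 of the 3 values shown sits). Compound 4 `CCCC/C=C\c1cn([C@H]2C[C@H](O)[C@@H](CO)O2)c(=O)[nH]c1=O` has not yet been measured. It differs from compound 2 in one place: hex-1-en-1-yl in place of 1-chloroethenyl on an aromatic carbon. Within the data shown here, no step between two measured compounds matches this change, so the expectation rests on compound 2 alone. Compound 4 is expected to give a weaker result, a rise in this assay a 12-fold higher number from compound 2 to compound 4 (1.08 log units; beyond the scatter). Compound 4 is estimated at 20000 nM, between 3000 nM and 150000 nM.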

Compound 4, half-maximal inhibitory concentration: > 200000 nM
Compound 4: only a limit was reported; the forecaster's own chance of this, stated with the estimate: 20%; middle value at least 10-fold (1.00 log units) away from the limit.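

Among the compounds shown, this is the only pair that differs in one place, and it shows that in this assay the aromatic carbon carrying 1-chloroethenyl does not tolerate every alkenyl group: hex-1-en-1-yl in place of 1-chloroethenyl gives an at least 120-fold higher number from compound 2 to compound 4 (2.08 log units; beyond the scatter). The value of compound 4 is a limit, so the step has no upper bound, and this limit is shared: the limit of > 200000 nM in this assay, at which 2 of the 4 values shown sit.

The compounds shown leave open whether plain ethenyl, without chlorine, would stay close to compound 2. They also leave open how a shorter chain such as but-1-en-1-yl would read at this position.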